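A few compounds are considered here, and "the series" means these few. Any claim that something is new, unique, unknown or untested is made for them only; others in the source may bear on it.

Measured in an ADME assay on L1210/0 cells (Mus musculus) for cytotoxicity, with a stated time of 48 h; a higher number here means a weaker inhibitor, a lower number a stronger inhibitor:
compound 1 `O=c1[nH]c(=O)n([C@H]2C[C@H](O)[C@@H](CO)O2)cc1/C=N/O`: 15500 nM
compound 2 `O=c1[nH]c(=O)n([C@H]2C[C@H](O)[C@@H](CO)O2)cc1[N+](=O)[O-]`: 130 nM
compound 3 `O=C(CI)NCc1cn([C@H]2C[C@H](O)[C@@H](CO)O2)c(=O)[nH]c1=O`: 107000 nM

In this assay compound 3 stands highest of the three at 107000 nM, and its steps to both others lie beyond the scatter. The next structure is compound 4 `O=c1[nH]c(=O)n([C@H]2C[C@H](O)[C@@H](CO)O2)cc1C#CCO`, with 3-hydroxyprop-1-yn-1-yl in place of (((iodomethyl)carbonyl)amino)methyl on an aromatic carbon.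

Among the compounds with values here, no measured compound carries the entering group, so the evidence is indirect. Within the data shown here, the steps that bear on the change are the two that introduce the leaving group: a 6.9-fold higher number from compound 1 to compound 3 (0.84 log units; beyond the scatter), which is modest, and an 820-fold higher number from compound 2 to compound 3 (2.92 log units; beyond the scatter), which is large. Among the measured compounds shown here, both raise the number, so removing that group should lower it, although this rests on only two steps. The size is less certain: a 120-fold lower number from compound 1 to compound 2 (2.08 log units; beyond the scatter) shows that the group at this place can shift the number widely. A modest drop is expected rather than a large one, in line with the smaller of the two steps. The expected change is an 8.9-fold lower number from compound 3 to compound 4 (0.95 log units; beyond the scatter). For compound 4 the estimated value is 12000 nM, with an expected range of 1500 nM to 70000 nM.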

Compound 4, half-maximal inhibitory concentration: > 200000 nM
Compound 4 was reported as a limit (the forecaster's own chance of this, stated with the estimate: 10%); at least 16-fold (1.22 log units) between middle value and limit.
By their numbers in this assay, from the lowest: compound 2; then compound 1; then compound 3. At a limit, above all of these: compound 4.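

In this assay compound 4 is recorded as a limit, not a number: the limit of > 200000 nM in this assay, at which 1 of the 4 values shown sits. Within the data shown here, the step of an at least 1.8-fold higher number from compound 3 to compound 4 (0.27 log units; that floor lies within the scatter) has a floor within the scatter, so it does not separate the two compounds, but it gives no sign of the drop that the earlier steps pointed to: replacing (((iodomethyl)carbonyl)amino)methyl with 3-hydroxyprop-1-yn-1-yl on this aromatic carbon does not lower the number. The other two steps are firmer, an at least 12-fold higher number from compound 1 to compound 4 (1.11 log units; beyond the scatter) and an at least 1500-fold higher number from compound 2 to compound 4 (3.18 log units; beyond the scatter), and they widen the range at this position, with the nitro of compound 2 still alone at the low end and both the oxime-bearing compound 1 and the two larger chains well above it.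

Going by these compounds, the limit hides how far compound 4 really lies from the other three, so the true size of all its steps stays open, and so does its order relative to compound 3. The compounds shown also leave open whether an amine, a carboxylic acid or an unsubstituted ethynyl group on this carbon would bring the number closer to that of compound 2.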